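Swapping bromo for methoxy on a curcumin-like core

The compounds below may be only part of what the source reports. "The series", "measured", "known", "first", "only" and "open" are said of these compounds alone.

Measured compounds:
- compound 1, `COc1ccc(/C=C/C(=O)C(=Cc2cc(Br)c(O)c(OC)c2)C(=O)/C=C/c2ccc(OC)cc2OC)c(OC)c1`: 1480 nM
- compound 2, `COc1ccc(/C=C/C(=O)C(=Cc2cc(OC)c(O)c(OC)c2)C(=O)/C=C/c2ccc(OC)cc2OC)c(OC)c1`: 850 nM
- compound 3, `COc1cc(OC)c(/C=C/C(=O)C(=Cc2cc(Br)c(O)c(OC)c2)C(=O)/C=C/c2c(OC)cc(OC)cc2OC)c(OC)c1`: 1450 nM

All three were tested in a functional assay on SW480 cells (Homo sapiens) for antiproliferative activity, read by sulforhodamine B assay, with a stated time of 48 h; a lower number here means a stronger inhibitor, a higher number a weaker inhibitor. Compound 1 and compound 2 share one core and differ by a single change, (methoxy in place of bromo on an aromatic carbon). That change gave a 1.7-fold lower number from compound 1 to compound 2 (0.24 log units; within the scatter), so the two values sit close together. Compound 3 carries a different core, and the difference between the two cores is not broken down here; its value in this assay lies near that of compound 1.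

Compound 4, `COc1cc(OC)c(/C=C/C(=O)C(=Cc2cc(OC)c(O)c(OC)c2)C(=O)/C=C/c2c(OC)cc(OC)cc2OC)c(OC)c1`, has not yet been measured. Going by the values given here, it differs from compound 3 by methoxy in place of bromo on an aromatic carbon, the same change, at the same place, as the one seen from compound 1 to compound 2. Among the compounds with values here, the expectation for compound 4 therefore rests on that earlier step: a number close to, or a little below, the value of compound 3, because a 1.7-fold lower number from compound 1 to compound 2 (0.24 log units; within the scatter) was the only time this change has been observed. Compound 4 is expected to give 900 nM, in the range 450 nM to 1800 nM, which means an estimated step of a 1.6-fold lower number from compound 3 to compound 4 (0.21 log units; within the scatter).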

Compound 4, half-maximal inhibitory concentration: 980 nM
Compound 4: middle estimate off by 1.1-fold (0.04 log units), on the low side, and the stated range covers the measured number.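

In this assay, replacing bromo with methoxy, which turns the 3-bromo-4-hydroxy-5-methoxyphenyl group into 4-hydroxy-3,5-dimethoxyphenyl, gave a 1.5-fold lower number from compound 3 to compound 4 (0.17 log units; within the scatter). Set side by side, the two steps agree, so the change carried over from one core to the other with a similar size: the same change on two cores in this assay, a 1.7-fold lower number (0.24 log units; within the scatter) from compound 1 to compound 2 and a 1.5-fold lower number (0.17 log units; within the scatter) from compound 3 to compound 4, 1.2-fold (0.07 log units) apart, within the scatter of two such steps

This does not show that methoxy truly outperforms bromo on either core, as each step on its own lies within the scatter, and two cores set no rule for other cores in this series.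

The compounds shown carry only bromo or methoxy at this place, so it remains open how a chloro group, an amine or a longer chain such as ethoxy would read there. The hydroxy group on the same ring is also present in all four compounds, which leaves open what a carboxylic acid in its place would do.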